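The compounds below may be only part of what the source reports. "The series", "measured", "known", "first", "only" and "open" are said of these compounds alone.

Measured so far in a functional assay on RT-112 cells (Homo sapiens) for antiproliferative activity, read by MTT assay, with a stated time of 72 h; on this read-out higher numbers stand for weaker inhibition of growth and lower numbers for stronger inhibition of growth:
compound 1, `COc1cc(NC(=O)Nc2cccc3c(Nc4cc(OC)cc(OC)c4)ncnc23)cc(OC)c1`: 366 nM
compound 2, `COc1cc(Nc2ncnc3c(NC(=O)Nc4cccc(Cl)c4Cl)cccc23)cc(OC)c1`: 63.2 nM
compound 3, `COc1cc(Nc2ncnc3c(NC(=O)Nc4ccc([N+](=O)[O-])cc4)cccc23)cc(OC)c1`: > 20000 nM

Compound 2 holds the lowest number of the two that are numbers; the nearest is compound 1, with a 5.8-fold lower number from compound 1 to compound 2 (0.76 log units; beyond the scatter) separating them. Compound 3 gives only a limit of the assay and not a number, as shown by the limit of > 20000 nM in this assay, at which 1 of the 3 values shown sits.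

The step to compound 4, `CCOC(=O)c1ccc(NC(=O)Nc2cccc3c(Nc4cc(OC)cc(OC)c4)ncnc23)cc1`, changes compound 2 in one place: 4-(ethoxycarbonyl)phenyl in place of 2,3-dichlorophenyl on an amide-type nitrogen. Two measured steps leave the 2,3-dichlorophenyl ring or reach a phenyl ring bearing a single substituent. The first, an at least 310-fold higher number from compound 2 to compound 3 (2.50 log units; beyond the scatter), runs to 4-nitrophenyl and ends at the limit. The second, an at least 54-fold higher number from compound 1 to compound 3 (1.73 log units; beyond the scatter), reaches the same 4-nitrophenyl from the 3,5-dimethoxyphenyl of compound 1 and likewise ends at the limit. Both point to a large loss when the 2,3-dichlorophenyl is given up for a single-substituent phenyl; whether an ethoxycarbonyl group behaves as a nitro group does is not shown, so the size is uncertain, though a step well beyond the scatter toward weaker inhibition is expected. Compound 4 is therefore estimated at 5000 nM, within 800 nM to 20000 nM, meaning an expected 79-fold higher number from compound 2 to compound 4 (1.90 log units; beyond the scatter); a limit rather than a number is a real possibility.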

Compound 4, concentration for 50% growth inhibition: 317 nM
Compound 4: middle estimate off by 16-fold (1.20 log units), on the high side, and the stated range ends above it.
By their numbers in this assay, from the lowest: compound 2; then compounds 4 and 1 (each within the scatter of the next). At a limit, above all of these: compound 3.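

On the amide-type nitrogen in this assay, a phenyl ring bearing a single substituent need not cost much: the 4-(ethoxycarbonyl)phenyl ring and the 3,5-dimethoxyphenyl ring cannot be told apart, with a 1.2-fold lower number from compound 1 to compound 4 (0.06 log units; within the scatter), and giving up the 2,3-dichlorophenyl ring for the 4-(ethoxycarbonyl)phenyl ring costs only a 5.0-fold higher number from compound 2 to compound 4 (0.70 log units; beyond the scatter). The collapse seen with 4-nitrophenyl therefore does not extend to every phenyl ring with a single substituent, and the identity of that substituent matters, as ethoxycarbonyl in place of nitro on an aromatic carbon gives an at least 63-fold lower number from compound 3 to compound 4 (1.79 log units; beyond the scatter). That step starts from compound 3, which gives a limit and not a number, so its full size stays unknown: the limit of > 20000 nM in this assay, at which 1 of the 4 values shown sits.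

Going by these compounds, how a carboxylic acid or a primary amide would read in place of the ethoxycarbonyl group remains open, so it cannot yet be said whether the ester itself matters. Also open, on these data alone, is whether the nitro result stands alone or is shared by other single substituents on the phenyl ring, such as a nitrile or an amine.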